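This account rests on a few compounds, and the source may have more. Where it says the series, first, only, none or still open, it means among the compounds named here.

Measured so far:
Compound 1, `O=C(O)CCCNCC(O)COc1cc(=O)oc2ccccc12`: "not determined" (no result reported)
Compound 2, `O=c1cc(OCC(O)CNC2CC2)c2ccccc2o1`: > 100000 nM
Compound 3, `O=c1cc(OCC(O)CN2CCCCC2)c2ccccc2o1`: "not determined" (no result reported)

The three compounds share one core, and all were sent to an ADME assay on Vero cells (Chlorocebus sabaeus) for cytotoxicity, read by fluorescence and resazurin assay, with a stated time of 72 h; a higher number here means that more compound is tolerated, a lower number that less compound is tolerated. Compound 1 has no result there, only the entry "not determined" (no result reported). Compound 2 reaches the upper limit of the assay, > 100000 nM, which is a limit and not a number. The one fixed point among the three results is therefore (the limit of > 100000 nM in this assay, at which 1 of the 3 values shown sits). Compound 3 stands without any number of its own in this assay; its entry reads "not determined" (no result reported), so there is no measured value to place it against compound 2.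

The next compound, compound 4 `CCCCNCC(O)COc1cc(=O)oc2ccccc12`, is reached from compound 3 by one change: butylamino in place of piperidin-1-yl on a saturated chain carbon, two bonds along the chain from an oxygen on a saturated carbon. Among the compounds with values here, no measured step between two compounds of this set exists, so the size of this step is open. With compound 2 tolerated up to the limit in this assay, the expectation is that the change from a cyclic to an open-chain amine moves tolerance by no more than the usual scatter, in no particular direction. Compound 4 is estimated to give 100000 nM, within a range from 30000 nM to 300000 nM, most likely again reported as a limit.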

Compound 4, half-maximal cytotoxic concentration: > 100000 nM
Compound 4: only a limit was reported (the forecaster's own chance of this, stated with the estimate: 70%); the middle value lies on the limit itself.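

The step from compound 2 to compound 4 in this assay cannot be read, since both results are limits of the assay and not numbers: the limit of > 100000 nM in this assay, at which 2 of the 4 values shown sit.

The compounds shown leave open whether butyl in place of cyclopropyl on an amine nitrogen changes tolerance at all in this assay.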